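A few compounds are considered here, and "the series" means these few. Any claim that something is new, unique, unknown or untested is made for them only; others in the source may bear on it.

Measured in a functional assay on DU-145 cells (Homo sapiens) for antiproliferative activity, read by sulforhodamine B assay, with a stated time of 3 days; a higher number here means a weaker inhibitor of growth, a lower number a stronger inhibitor of growth:
compound 1 `COc1ccc(N2CCN(C)CC2)cc1Nc1ncc(F)c(Nc2ccc(F)cc2)n1` gives 910 nM
compound 2 `O=C(Nc1ccc(C(F)(F)F)cc1)c1cccc(Nc2ncc(F)c(Nc3ccc(F)cc3)n2)c1` gives > 10000 nM as a limit
compound 3 `O=C(c1cccc(Nc2ncc(F)c(Nc3ccc(F)cc3)n2)c1)N1CCCCC1` gives 13000 nM

Compound 3 at 13000 nM has the higher of the two readable numbers, and compound 1 lies lower at 910 nM in the same assay. Compound 4 `O=C(Nc1cccc(Nc2ncc(F)c(Nc3ccc(F)cc3)n2)c1)c1ccccc1` carries benzamido in place of (piperidin-1-yl)carbonyl on an aromatic carbon and is otherwise unchanged. Among the compounds with values here, the one measured step that bears on this is a step that the limit leaves unreadable from compound 2 to compound 3 and its size cannot be read. Compound 2 gives only a limit of > 10000 nM and no number. So in this assay no step beyond the scatter is expected, in either direction. The estimated change is a 1.3-fold lower number from compound 3 to compound 4 (0.11 log units; within the scatter) and it rests on compound 3 at 13000 nM as the starting point. Compound 4 is expected at 10000 nM with an estimated range from 2500 nM to 30000 nM around it.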

Compound 4, concentration for 50% growth inhibition: > 10000 nM
Compound 4 gave a limit, no number; the forecaster's own chance of this, stated with the estimate: 45%; the middle value sits exactly at the limit.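

No step can be read from compound 3 to compound 4, because compound 4 gives only a limit and no number: the limit of > 10000 nM in this assay, at which 2 of the 4 values shown sit.

The compounds shown leave open whether compound 2 and compound 4 truly differ from compound 3 in growth inhibition.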